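Working notes: methoxy in place of hexyl

The source may report more compounds than this note shows. Statements on the series, on what has been measured and on what is new or still open speak of the compounds shown alone.

Measured in a functional assay (Homo sapiens) for inhibition; a higher number here means a weaker inhibitor, a lower number a stronger inhibitor:
- compound 1 `O=C(/C=C/c1ccc(F)cc1)c1ccc(C2CCCCC2)cc1` gives 74000 nM
- compound 2 `C=CCOc1ccc(C(=O)/C=C/c2cc(OC)cc(OC)c2)cc1` gives 25000 nM
- compound 3 `C=CCOc1ccc(C(=O)/C=C/c2cc(OC)c(CCCCCC)c(OC)c2)cc1` gives 15000 nM

Compound 3 at 15000 nM lies within the scatter of compound 2 at 25000 nM. Set against compound 1, compound 3 has the lower number, and the gap to compound 1, which gives 74000 nM, lies beyond the scatter. Next comes compound 4 `C=CCOc1ccc(C(=O)/C=C/c2cc(OC)c(OC)c(OC)c2)cc1`, with methoxy in place of hexyl on an aromatic carbon. Within the data shown here, one measured step bears on this carbon, a 1.7-fold lower number from compound 2 to compound 3 (0.22 log units; within the scatter), where hexyl replaced hydrogen. With that step inside the scatter, no step beyond the scatter is expected in this assay. The estimated step is a 1.3-fold higher number from compound 3 to compound 4 (0.12 log units; within the scatter). Compound 4 is expected at 20000 nM, with an estimated range of 8000 nM to 50000 nM.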

Compound 4, half-maximal inhibitory concentration: 30000 nM
Compound 4: the middle estimate sits 1.5-fold (0.18 log units) below what was measured; low and high end bracket the measured number.
By their numbers in this assay, from the lowest: compounds 3, 2 and 4 (each within the scatter of the next); then compound 1.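

At this aromatic carbon, ortho to two methoxy groups, hexyl, methoxy and hydrogen can now be compared in this assay. Methoxy stands within the scatter of both hexyl (a 2.0-fold higher number from compound 3 to compound 4 (0.30 log units; within the scatter)) and hydrogen (a 1.2-fold higher number from compound 2 to compound 4 (0.08 log units; within the scatter)), so neither exchange separates these compounds, even with the six heavy atoms of hexyl replaced by the two of methoxy. No supporting data bear on these readings.

Still open, as far as these compounds go, is whether an amine or a carboxylic acid on this carbon would give a step beyond the scatter.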